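Aryl change on the ring nitrogen: expectation for compound 4

The compounds below may be only part of what the source reports. "The series", "measured", "known", "first", "only" and "open" are said of these compounds alone.

Compound 1 `Cc1n[nH]c2ccc(-c3nc4cnc(N5CCN(C)CC5)cn4c3Nc3ccccc3F)cc12` and compound 2 `Cc1n[nH]c2ccc(-c3nc4cnc(N5CCN(C)CC5)cn4c3Nc3ccc(Cl)cc3)cc12` share one core and differ only in the aryl group on a nitrogen on an aromatic ring. In a functional assay on CWR22R cells (Homo sapiens) for inhibition, with a stated time of 120 h, tested at 10 uM (a lower number here means less inhibition, a higher number more inhibition at the concentration tested (going by the name of the read-out)), compound 1 gives 0%, and compound 2 gives 8.11%, so the step of a number 8.1 percentage points higher from compound 1 to compound 2 (within the scatter). Compound 3 `Cc1n[nH]c2ccc(-c3nc4cnc(N5CCN(C)CC5)cn4c3Nc3ccc(I)cc3)cc12` carries a 4-iodophenyl at that position; in this assay compound 3 gives "not determined" (no result reported), and it therefore stands on no number at all. Compound 4 `COc1ccc(Nc2c(-c3ccc4[nH]nc(C)c4c3)nc3cnc(N4CCN(C)CC4)cn23)cc1OC` differs from compound 3 by 3,4-dimethoxyphenyl in place of 4-iodophenyl on a nitrogen on an aromatic ring. For the measured compounds named here, no measured step covers this exchange; the single measured change of the aryl at this position stayed within the scatter, and both known values sit near the floor. Compound 4 is therefore expected in this assay to give about 6%, estimated between 0% and 22%.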

Compound 4, a percentage reported as inhibition, at one concentration (the size of the read-out at that concentration, not a potency): 0%
Compound 4: middle estimate off by 6 percentage points, on the high side, within the range that was stated.
By their numbers in this assay, from the lowest: compounds 1, 4 and 2 (each within the scatter of the next).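

Replacing the aryl on the nitrogen with 3,4-dimethoxyphenyl gives a number 8.1 percentage points lower from compound 2 to compound 4 (within the scatter) and no change at the digits printed from compound 1 to compound 4 (within the scatter) in this assay. The position has now taken three different aryl groups, including one with two hydrogen-bond acceptors, and all readings remain near the floor with no separation among them. Nothing at hand bears on why these readings stay together. Going by these compounds, whether an aryl carrying an aminomethyl group or a carboxylic acid, or a cyclohexyl in place of the aryl, would raise the inhibition stays open.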